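Replacing Carbamoyl with Methanesulfonamido on the Shared Core

The compounds below may be only part of what the source reports. "The series", "measured", "known", "first", "only" and "open" are said of these compounds alone.

In a functional assay on KB cells (nasopharynx, Homo sapiens) for antiproliferative activity (a higher number here means a weaker inhibitor, a lower number a stronger inhibitor), compound 1 (`COc1ccc(S(=O)(=O)Nc2cccc3c(Cl)c[nH]c23)cc1`) gives 0.55 ug/mL with methoxy at the varied position. Compound 2 (`N#Cc1ccc(S(=O)(=O)Nc2cccc3c(Cl)c[nH]c23)cc1`) gives 11 ug/mL with cyano there, and compound 3 (`NC(=O)c1ccc(S(=O)(=O)Nc2cccc3c(Cl)c[nH]c23)cc1`) gives 21 ug/mL with carbamoyl. Compound 3 carries the highest of the three numbers, but the smallest gap is only a 1.9-fold higher number from compound 2 to compound 3 (0.28 log units; within the scatter) and lies within the scatter. Its gap to compound 1 is large, at a 38-fold higher number from compound 1 to compound 3 (1.58 log units; beyond the scatter) on the same read-out, and a similar gap appears as a 20-fold higher number from compound 1 to compound 2 (1.30 log units; beyond the scatter) between the other pair.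

Compound 4 (`CS(=O)(=O)Nc1ccc(S(=O)(=O)Nc2cccc3c(Cl)c[nH]c23)cc1`) brings methanesulfonamido in place of carbamoyl on an aromatic carbon, para to a large group: methanesulfonamido in place of carbamoyl on an aromatic carbon is the change. Of the groups measured, only the methoxy of compound 1 is joined through an atom other than carbon, as in compound 4, and compound 1 gives 0.55 ug/mL here. A partial move toward that number is therefore expected, not a full one.

The estimated change is a 7.0-fold lower number from compound 3 to compound 4 (0.85 log units; beyond the scatter) in this reading. For compound 4 the expected value is 3 ug/mL within an estimated range of 0.6 ug/mL to 15 ug/mL overall.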

Compound 4, half-maximal inhibitory concentration: 12 ug/mL
The estimate for compound 4 lay 4.0-fold (0.60 log units) below the measured number; the range from low to high includes it.
By their numbers in this assay, from the lowest: compound 1; then compounds 2, 4 and 3 (each within the scatter of the next).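

In this assay, methanesulfonamido cannot be told apart from the two carbon-joined groups: a 1.8-fold lower number from compound 3 to compound 4 (0.24 log units; within the scatter) and a 1.1-fold higher number from compound 2 to compound 4 (0.04 log units; within the scatter), while a 22-fold higher number from compound 1 to compound 4 (1.34 log units; beyond the scatter) leaves compound 1 as the strongest inhibitor of the four. Compound 4 thus shows that being joined to the ring through an atom other than carbon is not enough at this position to reach the number of compound 1, and methoxy alone stands apart among the groups compared. No available evidence bears on what sets methoxy apart here. Going by these compounds, what remains open is whether another oxygen-joined group, such as ethoxy or hydroxyl, would stay close to compound 1. On these data alone, it is equally open whether a simple amine or a methyl group would instead fall with compounds 2, 3 and 4.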